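Diacylhydrazine series: halogen swap on the benzoyl ring

A few compounds are considered here, and "the series" means these few. Any claim that something is new, unique, unknown or untested is made for them only; others in the source may bear on it.

Measured so far:
Compound 1, `Cc1ccccc1C(=O)NN(C(=O)c1ccccc1Cl)C(C)(C)C`: 72.4 nM
Compound 2, `CC(C)(C)N(NC(=O)c1cccc(F)c1)C(=O)c1ccccc1Cl`: 69.2 nM

Both compounds share one core and differ only in the benzoyl ring on the hydrazide side. In an assay on cells for agonist activity at ecdysone receptor (Bombyx mori), read by a luciferase reporter, with a stated time of 24 h (a lower number here means that less compound is needed, a higher number that more compound is needed for the effect), compound 1 gives 72.4 nM, and compound 2 gives 69.2 nM. The step of a 1.0-fold lower number from compound 1 to compound 2 (0.02 log units; within the scatter) is within the scatter, so compound 2 stands with the lower of the two numbers but cannot be set apart from compound 1.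

Compound 3, `CC(C)(C)N(NC(=O)c1cccc(Cl)c1)C(=O)c1ccccc1Cl`, has not been measured. It differs from compound 2 by chloro in place of fluoro on an aromatic carbon. Among the compounds with values here, no measured step covers this change directly; the only step in hand, a 1.0-fold lower number from compound 1 to compound 2 (0.02 log units; within the scatter), shows that reworking this ring left the number essentially unchanged. The expected step of a 1.2-fold lower number from compound 2 to compound 3 (0.06 log units; within the scatter) is therefore small, in either direction, and not beyond the scatter. Compound 3 is estimated to give 60 nM in this assay, within the range 25 nM to 160 nM.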

Compound 3, half-maximal effective concentration: 155 nM
For compound 3 the middle estimate is 2.6-fold (0.41 log units) below the measured one, and the stated range covers the measured number.
By their numbers in this assay, from the lowest: compounds 2 and 1 (each within the scatter of the next); then compound 3.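

In this assay, within the data shown here, chloro in place of fluoro on an aromatic carbon gives a 2.2-fold higher number from compound 2 to compound 3 (0.35 log units; beyond the scatter) and is the first change to lie beyond the scatter, though only modestly. The position therefore distinguishes between these two halogens, which the earlier comparison could not show. The 3-chlorophenyl group also separates from the 2-methylphenyl group, with a 2.1-fold higher number from compound 1 to compound 3 (0.33 log units; beyond the scatter) in place of the indistinguishable pair seen for 3-fluorophenyl. No measurement at hand accounts for the step.

Going by these compounds, it remains open how bromo, methoxy or an amine would read at this same place on the ring. Also open, on these data alone, is whether chloro elsewhere on this ring, or a similar swap on the other benzoyl ring, gives a step of similar size.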